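Hydrogen for fluoro on the shared core: compound 4

The compounds below may be only part of what the source reports. "The series", "measured", "known", "first", "only" and "open" are said of these compounds alone.

Measured compounds in a functional assay on the whole organism (strain NMRI) with Mus musculus as the target, with a stated time of 5 min; a higher number here means that more compound is needed for the effect, a lower number that less compound is needed:
compound 1 `CCC1(CCCCN2CCN(c3cccc(Cl)c3)CC2)C(=O)Nc2cc(F)ccc21`: "not determined" (no result reported)
compound 2 `CCC1(CCCCN2CCN(c3ccc(Cl)cc3)CC2)C(=O)Nc2cc(F)ccc21`: > 10 mg/kg
compound 3 `CCC1(CCCCN2CCN(c3cccc(Cl)c3)CC2)C(=O)Nc2cc(F)c(Cl)cc21`: "not determined" (no result reported)

Compound 1 has no number in this assay, so it cannot be placed against the others. Among the measured compounds shown here, compound 2 gives only a limit in this assay, > 10 mg/kg, and the single firm piece of evidence in the set is the limit of > 10 mg/kg in this assay, at which 1 of the 3 values shown sits. Compound 3 likewise carries no result in this assay. For the measured compounds named here, no step between two measured compounds exists here, so nothing in the set shows how large a change of this kind is.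

Compound 4 `CCC1(CCCCN2CCN(c3cccc(Cl)c3)CC2)C(=O)Nc2ccccc21` is the unmeasured member. It differs from compound 1 by hydrogen in place of fluoro on an aromatic carbon. Going by the values given here, since compound 1 has no value in this assay, the direction and size of the step to compound 4 cannot be read from the set, and the one limit of compound 2 only indicates where a member of the series has sat. Compound 4 is expected to come out near 10 mg/kg, with the likely range between 3 mg/kg and 30 mg/kg, and a limit rather than a number is considered quite possible.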

Compound 4, minimum effective dose: > 10 mg/kg
Compound 4 gave a limit, no number; the forecaster's own chance of this, stated with the estimate: 50%; the middle value lies on the limit itself.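

In this assay compound 4 gives > 10 mg/kg, a limit and not a number. Among the compounds shown here, compound 1 has no number either, so no step between compound 1 and compound 4 can be read. The compounds shown leave open what exchanging fluoro for hydrogen does to the minimum effective dose in this assay.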